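This account rests on a few compounds, and the source may have more. Where it says the series, first, only, none or still open, it means among the compounds named here.

Measured in an ADME assay on RAW264.7 cells (Mus musculus) for cytotoxicity, read by MTT assay, with a stated time of 72 h, tested at 50 uM; on this read-out lower numbers stand for less inhibition and higher numbers for more inhibition at the one concentration tested (going by the name of the read-out):
compound 1, `CCOC(=O)c1sc(-c2ccccc2)nc1N1CCC(NCc2ccc(OCc3ccccc3)cc2)CC1`, gives 18.4%
compound 2, `CCOC(=O)c1sc(-c2ccccc2)nc1N1CCC(NCc2ccc(C(F)(F)F)cc2)CC1`, gives 22.7%
compound 3, `CCOC(=O)c1sc(-c2ccccn2)nc1N1CCC(NCc2ccc(OCc3ccccc3)cc2)CC1`, gives 12.8%

Compound 4, `CCOC(=O)c1sc(-c2ccccn2)nc1N1CCC(NCc2ccc(C(F)(F)F)cc2)CC1`, has not yet been measured in this assay.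

Compound 1 and compound 2 share one core; compound 3 and compound 4 share the other. The two cores differ by pyridin-2-yl in place of phenyl on an aromatic carbon. That difference is measured once: a number 5.6 percentage points lower from compound 1 to compound 3 (within the scatter).

The change from compound 3 to compound 4 is trifluoromethyl in place of benzyloxy on an aromatic carbon. The same change, (trifluoromethyl in place of benzyloxy on an aromatic carbon), is measured from compound 1 to compound 2: a number 4.3 percentage points higher from compound 1 to compound 2 (within the scatter). The place of the change reads the same in both pairs, so the change from compound 3 to compound 4 is taken as the same change, carried onto the other core.

The three measured numbers all lie within the scatter of one another, so no order among them is claimed, and nothing here separates the two cores in this read-out.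

Because a number 4.3 percentage points higher from compound 1 to compound 2 (within the scatter) lies within the scatter, a step of similar small size is expected for compound 4 in this assay: a number 4.2 percentage points higher from compound 3 to compound 4 (within the scatter). This rests on a single measured instance of the change, on one core only, and on the small size of the core step itself. Compound 4 is therefore estimated at 17%, with an expected range from 7% to 27%.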

Compound 4, a percentage reported as inhibition, at one concentration (the size of the read-out at that concentration, not a potency): 14.6%
The estimate for compound 4 lay 2.4 percentage points above the measured number; the measured number falls inside the stated range.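

Carrying trifluoromethyl in place of benzyloxy onto the second core gives a number 1.8 percentage points higher from compound 3 to compound 4 (within the scatter), and in this assay the two readings of this change agree: the same change on two cores in this assay, a number 4.3 percentage points higher (within the scatter) from compound 1 to compound 2 and a number 1.8 percentage points higher (within the scatter) from compound 3 to compound 4, 2.5 percentage points apart, within the scatter of two such steps

Pyridin-2-yl in place of phenyl, read on the second pair, gives a number 8.1 percentage points lower from compound 2 to compound 4 (within the scatter), and this too agrees with its earlier reading: the same change on two cores in this assay, a number 5.6 percentage points lower (within the scatter) from compound 1 to compound 3 and a number 8.1 percentage points lower (within the scatter) from compound 2 to compound 4, 2.5 percentage points apart, within the scatter of two such steps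

Within these four compounds, the size of each change therefore shows no measurable dependence on the other, but every step lies within the scatter, so the agreement is only between small steps and does not show that either change has a real effect on this read-out, or that a step large enough to stand clear of the scatter would carry from one core to the other in the same way.

The compounds shown leave open whether this agreement extends to other groups on the same aromatic carbon, such as a nitrile, a carboxylic acid or a primary amine, or to an amide in place of the ethyl ester. They also leave open how these compounds compare at any concentration other than the one tested.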